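From 5-nitrothiophen-2-yl to 5-nitrofuran-2-yl in Compound 4

The source may hold more compounds than are shown below. What is called first, only, known or untested is meant among the compounds shown, and "the series" means these compounds.

Three related compounds have numbers in a functional assay on M14 cells (Homo sapiens) for inhibition, read by sulforhodamine B assay, with a stated time of 48 h; a lower number here means a stronger inhibitor of growth, a higher number a weaker inhibitor of growth. Compound 1 `O=C(NNC(=O)c1ccc2[nH]c(-c3ccc([N+](=O)[O-])o3)nc2c1)c1ccccc1` gives 15.6 ug/mL, compound 3 `O=CNNC(=O)c1ccc2[nH]c(-c3ccc([N+](=O)[O-])o3)nc2c1` gives 31.3 ug/mL, and compound 2 `COc1cc(C(=O)NNC(=O)c2ccc3[nH]c(-c4ccc([N+](=O)[O-])s4)nc3c2)cc(OC)c1OC` gives 62.5 ug/mL. The number for compound 2 lies within the scatter of that for compound 3, but beyond the scatter above that for compound 1.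

Compound 4 `COc1cc(C(=O)NNC(=O)c2ccc3[nH]c(-c4ccc([N+](=O)[O-])o4)nc3c2)cc(OC)c1OC` differs from compound 2 in one place: 5-nitrofuran-2-yl in place of 5-nitrothiophen-2-yl on an aromatic carbon. This puts 5-nitrofuran-2-yl in place of 5-nitrothiophen-2-yl on an aromatic carbon. For the measured compounds named here, no measured pair isolates this swap. Going by the values given here, the only measured step, a 2.0-fold higher number from compound 1 to compound 3 (0.30 log units; within the scatter), concerns a different place, where hydrogen replaces phenyl on a carbonyl carbon, so it bears on the swap only indirectly. It does suggest that the group at that carbonyl need not shift the number much. Both compounds with the entering group sit low, with compound 1 at 15.6 ug/mL and compound 3 at 31.3 ug/mL, so a small move toward a lower number is expected. The expected step is a 2.0-fold lower number from compound 2 to compound 4 (0.30 log units; within the scatter). Compound 4 is estimated at 31.3 ug/mL, within a range of 12 ug/mL to 80 ug/mL.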

Compound 4, concentration for 50% growth inhibition: 15.6 ug/mL
Estimate against measurement, compound 4: 2.0-fold (0.30 log units) above, and the stated range covers the measured number.
By their numbers in this assay, from the lowest: compounds 1, 4, 3 and 2 (each within the scatter of the next, the first and the last beyond it).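

In this assay, placing 5-nitrofuran-2-yl in place of 5-nitrothiophen-2-yl on this aromatic carbon, between two ring nitrogen atoms, gives a 4.0-fold lower number from compound 2 to compound 4 (0.60 log units; beyond the scatter). For the compounds shown here, this is the first measured step at this position, and it lies beyond the usual scatter even though the two groups differ only in having oxygen rather than sulfur in the five-membered ring. The earlier compounds shown here offered only a step at the carbonyl end of the molecule, so they could not show that this position responds to such a small exchange. Nothing in the available data explains the size of this step.

Going by these compounds, it remains open whether the same swap has a similar effect when the trimethoxybenzoyl group is replaced by the benzoyl or formyl group of compound 1 or compound 3. On these data alone, how an amine or a carboxylic acid would behave at this position also remains open.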